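Aryl Variation on a Triazole Nitrogen: Expectation for Compound 3

The compounds below may be only part of what the source reports. "The series", "measured", "known", "first", "only" and "open" are said of these compounds alone.

Compound 1 `COc1ccc(-n2nncc2CN2C(=O)C3(C(C#N)=C(N)Oc4c(N)cc5nc6ccccc6nc5c43)c3ccccc32)cc1` in a functional assay on MCF7 cells (Homo sapiens) for antiproliferative activity, read by MTT assay, with a stated time of 48 h; a lower number here means a stronger inhibitor, a higher number a weaker inhibitor: > 50000 nM, a limit of the assay.
Compound 2 `Cc1cc(C)cc(-n2nncc2CN2C(=O)C3(C(C#N)=C(N)Oc4c(N)cc5nc6ccccc6nc5c43)c3ccccc32)c1` in this assay: > 50000 nM, also a limit.

The account follows the move from compound 2 to compound 3 `N#CC1=C(N)Oc2c(N)cc3nc4ccccc4nc3c2C12C(=O)N(Cc1cnnn1-c1ccc(Cl)cc1[N+](=O)[O-])c1ccccc12`. Going by the values given here, compound 2 stands at a limit, and the only value it can be set beside is likewise a limit, so the step that the two limits leave unreadable from compound 1 to compound 2 cannot be read; both values sit at the limit of > 50000 nM in this assay, at which 2 of the 2 values shown sit. The change is 4-chloro-2-nitrophenyl in place of 3,5-dimethylphenyl on an aromatic nitrogen. Among the compounds with values here, no measured step bears on this new aryl group, and the two limits give no direction. Compound 3 is therefore expected to stay near the limit, estimated at 50000 nM (range 15000 nM to 150000 nM). The expected step is a number no higher from compound 2 to compound 3 (the limit leaves the size open).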

Compound 3, half-maximal inhibitory concentration: > 50000 nM
Compound 3 gave a limit, no number; the forecaster's own chance of this, stated with the estimate: 75%; the middle value sits exactly at the limit.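

Compound 1, compound 2 and compound 3 all stand at a limit in this assay, so no step among them can be read: the limit of > 50000 nM in this assay, at which 3 of the 3 values shown sit.

The compounds shown leave open whether any aryl group on this aromatic nitrogen gives a readable number in this assay.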